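The compounds below may be only part of what the source reports. "The series", "measured", "known", "first", "only" and "open" are said of these compounds alone.

Of the compounds shown here, three with a shared core have been measured in an assay on isolated protein for displacement of a labelled ligand from metabotropic glutamate receptor 5 (Homo sapiens), with a stated time of 60 min, tested at 1 uM; a lower number here means less inhibition, a higher number more inhibition at the concentration tested (going by the name of the read-out). Compound 1, `COc1ccc2ncc(S(=O)(=O)c3ccc(Cl)cc3)c(N3CCC(C)CC3)c2c1`, gives 91%, and compound 2, `COc1ccc2ncc(S(=O)(=O)c3cccc(C#N)c3)c(N3CCC(C)CC3)c2c1`, gives 90%. Compound 3, `COc1ccc2ncc(S(=O)(=O)c3ccc(F)cc3)c(N3CCC(C)CC3)c2c1`, gives 27%, and it stands lowest of the three numbers: its nearest neighbour is compound 2, with the step of a number 63 percentage points lower from compound 2 to compound 3 (beyond the scatter), and the furthest is compound 1, with the step of a number 64 percentage points lower from compound 1 to compound 3 (beyond the scatter). The step of a number 1 percentage points lower from compound 1 to compound 2 (within the scatter) shows that the 4-chlorophenyl and the 3-cyanophenyl on the sulfonyl sulfur give numbers within the scatter of one another.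

The next compound, compound 4, is `COc1cccc(S(=O)(=O)c2cnc3ccc(OC)cc3c2N2CCC(C)CC2)c1`. Its change from compound 3 is 3-methoxyphenyl in place of 4-fluorophenyl on a sulfonyl sulfur. Going by the values given here, two measured steps bear on it. Both of them swap the group on the sulfonyl sulfur and both are large: the step of a number 63 percentage points lower from compound 2 to compound 3 (beyond the scatter) shows that bringing in the 4-fluorophenyl came with a large drop in one direction, so the reverse exchange, away from the 4-fluorophenyl, has so far come with a large rise. Whether a 3-methoxyphenyl behaves like the 3-cyanophenyl or like the 4-fluorophenyl is not known from these compounds, so the expectation is a rise of a number 45 percentage points higher from compound 3 to compound 4 (beyond the scatter) with a wide range. Compound 4 is therefore expected to reach 72%, estimated to lie between 35% and 95%.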

Compound 4, a percentage reported as inhibition, at one concentration (the size of the read-out at that concentration, not a potency): 0%
For compound 4 the middle estimate is 72 percentage points above the measured one; the measured number lies below the stated range.
By their numbers in this assay, from the lowest: compound 4; then compound 3; then compounds 2 and 1 (each within the scatter of the next).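

In this assay, going by these compounds alone, the group on the sulfonyl sulfur turns out to be more sensitive than the earlier compounds could show: the 3-cyanophenyl and the 3-methoxyphenyl carry their groups at the same printed ring position, yet methoxy in place of cyano gives a number 90 percentage points lower from compound 2 to compound 4 (beyond the scatter) and so a 3-substituted phenyl is not enough on its own. The exchange of 4-chlorophenyl for 3-methoxyphenyl gives a similar result, a number 91 percentage points lower from compound 1 to compound 4 (beyond the scatter), and moving away from the 4-fluorophenyl, which had the lowest number until now, does not by itself bring a rise, as a number 27 percentage points lower from compound 3 to compound 4 (beyond the scatter) shows. No measurement here explains why these exchanges on the sulfonyl sulfur change the number so much.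

The compounds shown leave open whether the ring position or the group itself matters more, and a 3-chlorophenyl or a 4-cyanophenyl on the sulfonyl sulfur would help separate the two. Going by these compounds, it also remains open whether a 4-methoxyphenyl or a 3-hydroxyphenyl would behave like the 3-methoxyphenyl.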